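The source may report more compounds than this note shows. Statements on the series, on what has been measured and on what is new or still open speak of the compounds shown alone.

Going by the values given here, compound 1 `O=C(O)C1CC1c1ccc(C#Cc2cc(Cl)nc(Cl)c2)cc1` is one of three compounds measured in an in vitro functional assay on 1321-N1 cells for agonist activity at Free fatty acid receptor 1 (Homo sapiens), read by fluorescence, spectrophotometry and calcium flux; on this read-out lower numbers stand for an effect already at smaller amounts and higher numbers for an effect only at larger amounts of compound. In this assay compound 1 gives 42.7 nM, the lowest of the three numbers. The other two compounds carry a 2-carboxyethyl chain rather than a cyclopropane ring, and they also differ from compound 1 in their second aromatic ring: compound 2 `Cc1cc(C#Cc2ccc(CCC(=O)O)cc2)ccn1` gives 1120 nM, and compound 3 `Cc1cnc(F)c(C#Cc2ccc(CCC(=O)O)cc2)c1` gives 661 nM. Both numbers lie beyond the usual scatter from that of compound 1, the nearer being compound 3 and the farther compound 2. As compounds 2 and 3 differ from compound 1 in two places at once, their numbers cannot be split between the two changes.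

Compound 4 `O=C(O)CCc1ccc(C#Cc2cc(Cl)nc(Cl)c2)cc1` keeps the core and the second ring of compound 1 and alters only the acid-bearing group: 2-carboxyethyl in place of 2-carboxycyclopropyl on an aromatic carbon. Among the compounds with values here, no measured pair differs in this one place, so the size of the step has no measured example. The two measured carriers of the 2-carboxyethyl chain, compound 2 at 1120 nM and compound 3 at 661 nM, both sit well beyond compound 1. On that basis the step from compound 1 to compound 4 is expected to run toward larger numbers, about a 4.7-fold higher number from compound 1 to compound 4 (0.67 log units; beyond the scatter). Compound 4 is therefore estimated at 200 nM, with a range from 60 nM to 700 nM.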

Compound 4, half-maximal effective concentration: 40.7 nM
Compound 4: the middle estimate sits 4.9-fold (0.69 log units) above what was measured; the measured number lies below the stated range.
By their numbers in this assay, from the lowest: compounds 4 and 1 (each within the scatter of the next); then compounds 3 and 2 (each within the scatter of the next).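

In this assay, going by these compounds alone, replacing the 2-carboxycyclopropyl with 2-carboxyethyl on this aromatic carbon gives a 1.0-fold lower number from compound 1 to compound 4 (0.02 log units; within the scatter), the first reading of this change on its own, and with the second ring of compound 1 held fixed, the three-membered ring makes no difference beyond the scatter. The chain alone therefore does not go with large numbers: compound 2 gives 1120 nM and compound 3 gives 661 nM, yet both differ from compound 4 only in the second ring, which places their gap from compound 4 at that ring. Nothing at hand explains why the two acid-bearing groups read alike.

From the compounds shown here alone, it remains open whether the same equivalence would hold with the second rings of compound 2 and compound 3, where a 2-carboxycyclopropyl partner would be needed for a direct comparison. Also open, going by these compounds, is how far this position tolerates other changes, such as a longer chain like 3-carboxypropyl, or a tetrazole or primary amide in place of the carboxylic acid.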